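The source may hold more compounds than are shown below. What is called first, only, known or untested is meant among the compounds shown, and "the series" means these compounds.

Measured so far in an ADME assay on HEK293 cells (Homo sapiens) for cytotoxicity, read by sulforhodamine B assay, with a stated time of 48 h, tested at 10 uM; a higher number here means more inhibition at the concentration tested (going by the name of the read-out), a lower number less inhibition:

- compound 1, `CCCCCCc1cn(C(c2ccccc2)c2cc3cc(Br)ccc3nc2OC)nn1`: -3.17%
- compound 2, `CCCCc1cn(C(c2ccccc2)c2cc3cc(Br)ccc3nc2OC)nn1`: -3.47%
- compound 3, `CCCCCc1cn(C(c2ccccc2)c2cc3cc(Br)ccc3nc2OC)nn1`: -2%

Three chain homologues on a shared core, differing only in the length of the saturated chain on the triazole. In this assay compound 3 gives the highest of the three numbers shown, but neither gap reaches beyond the scatter: a number 1.2 percentage points higher from compound 1 to compound 3 (within the scatter) and a number 1.5 percentage points higher from compound 2 to compound 3 (within the scatter). The remaining pair behaves the same way: a number 0.3 percentage points lower from compound 1 to compound 2 (within the scatter). All three numbers sit near zero, so none of these compounds shows appreciable cytotoxicity at the concentration tested.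

Compound 4, `CCCc1cn(C(c2ccccc2)c2cc3cc(Br)ccc3nc2OC)nn1`, shortens the chain once more: hydrogen in place of ethyl on a saturated chain carbon, three bonds along the chain from an aromatic carbon. The three measured steps all concern the same chain at neighbouring lengths and all lie within the scatter, so the step to compound 4 is expected to be of the same kind, with no movement beyond the scatter in this assay in either direction.

For compound 4 the expected value in this assay is -2.5%, with a range from -12% to 7%, which means an expected step of a number 0.5 percentage points lower from compound 3 to compound 4 (within the scatter).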

Compound 4, a percentage reported as inhibition, at one concentration (the size of the read-out at that concentration, not a potency): 0.85%
Compound 4: middle estimate off by 3.4 percentage points, on the low side; low and high end bracket the measured number.
By their numbers in this assay, from the lowest: compounds 2, 1, 3 and 4 (each within the scatter of the next).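

Across the propyl to hexyl chains, shortening to the propyl chain produces no step beyond the scatter in this assay: a number 2.9 percentage points higher from compound 3 to compound 4 (within the scatter), a number 4.3 percentage points higher from compound 2 to compound 4 (within the scatter) and a number 4 percentage points higher from compound 1 to compound 4 (within the scatter). Hydrogen in place of ethyl reads alike at two chain lengths: the same change on two cores in this assay, a number 0.3 percentage points lower (within the scatter) from compound 1 to compound 2 and a number 2.9 percentage points higher (within the scatter) from compound 3 to compound 4, 3.2 percentage points apart, within the scatter of two such steps. Hydrogen in place of methyl does the same: the same change on two cores in this assay, a number 1.2 percentage points higher (within the scatter) from compound 1 to compound 3 and a number 4.3 percentage points higher (within the scatter) from compound 2 to compound 4, 3.2 percentage points apart, within the scatter of two such steps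

Going by these compounds, whether chain length matters at all outside this range stays open, since a methyl chain or a longer chain such as decyl could behave differently. A chain carrying an amine or a carboxylic acid is also untested by the compounds shown, so these results say nothing about how such groups would read in this assay.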